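The source may report more compounds than this note shows. Statements on the series, on what has been measured and on what is new or still open speak of the compounds shown alone.

In a functional assay on K562 cells (Homo sapiens) for inhibition, read by MTT assay, with a stated time of 48 h (a higher number here means a weaker inhibitor, a lower number a stronger inhibitor), compound 3 (`C=CC(=O)Nc1ccc(-c2cn([C@@H]3CN[C@H](C(=O)Nc4ccc(Cl)c(C(F)(F)F)c4)C3)nn2)cn1`) gives 3860 nM. Compound 1 (`CC(C)(C)OC(=O)N1C[C@@H](n2cc(-c3ccc(N)nc3)nn2)C[C@H]1C(=O)Nc1ccc(Cl)c(C(F)(F)F)c1`) gives 4710 nM, which is within the scatter of compound 3, while compound 2 (`CC(C)(C)C(=O)Nc1ccc(-c2cn([C@@H]3CN[C@H](C(=O)Nc4ccc(Cl)c(C(F)(F)F)c4)C3)nn2)cn1`) gives a clearly higher 43800 nM. Compound 4 (`Nc1n[nH]c2cc(-c3cn([C@@H]4CN[C@H](C(=O)Nc5ccc(Cl)c(C(F)(F)F)c5)C4)nn3)ccc12`) has not yet been measured. It keeps the core of compound 3 but carries 3-amino-1H-indazol-6-yl in place of 6-((vinylcarbonyl)amino)pyridin-3-yl on an aromatic carbon.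

Among the compounds with values here, only one measured step bears on this change: an 11-fold lower number from compound 2 to compound 3 (1.05 log units; beyond the scatter), where vinyl replaces tert-butyl on a carbonyl carbon. That large step shows the number can move strongly when this part of the molecule is altered. However, it changes only a small piece, whereas compound 4 replaces the whole group, so it gives no direction. No step beyond the scatter is therefore expected, though with wide uncertainty, and the estimated step is a 1.2-fold higher number from compound 3 to compound 4 (0.07 log units; within the scatter). For compound 4, the expected value is 4500 nM, with an estimated range from 900 nM to 22000 nM.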

Compound 4, half-maximal inhibitory concentration: 8320 nM
Beside the measured number, compound 4's estimate is 1.8-fold (0.27 log units) below it, within the range that was stated.
By their numbers in this assay, from the lowest: compounds 3, 1 and 4 (each within the scatter of the next, the first and the last beyond it); then compound 2.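

In this assay, exchanging the whole 6-((vinylcarbonyl)amino)pyridin-3-yl group for 3-amino-1H-indazol-6-yl gives a 2.2-fold higher number from compound 3 to compound 4 (0.33 log units; beyond the scatter). The earlier step altered only a small piece of this group, whereas this one shows that a complete replacement, with a different ring system and no carbonyl, costs only a modest rise: compound 4, at 8320 nM, still stands well below compound 2, at 43800 nM. No measurement available here explains the rise from compound 3 to compound 4.

Going by these compounds, this single exchange changes the rings and their attached groups together, so the share of each remains unknown. Open questions include how the number would respond if a hydroxyl or a methyl replaced the amino group on 3-amino-1H-indazol-6-yl, and whether a carboxylic acid at this position would fit the same trend.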